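A few compounds are considered here, and "the series" means these few. Any claim that something is new, unique, unknown or untested is made for them only; others in the source may bear on it.

- Compound 1 `COc1c(OCCCCNCc2ccccc2)cc(O)c2c(=O)cc(-c3ccccc3)oc12`: 4590 nM
- Compound 2 `CCCNCCOc1c(O)cc(O)c2c(=O)cc(-c3ccccc3)oc12`: "not determined" (no result reported)

Within the data shown here, in a functional assay on A549 cells (Homo sapiens) for cytotoxicity, read by MTT assay, with a stated time of 48 h (on this read-out higher numbers stand for weaker inhibition and lower numbers for stronger inhibition), compound 1 gives 4590 nM, the only number available, so it cannot yet be ranked against anything. No result exists for compound 2. Compound 3 `COc1c(OCCCNCc2ccccc2)cc(O)c2c(=O)cc(-c3ccccc3)oc12` differs from compound 1 in one place: benzylamino in place of (benzylamino)methyl on a saturated chain carbon, three bonds along the chain from an oxygen on an aromatic ring. Benzylamino stands in place of (benzylamino)methyl on a saturated chain carbon. Among the measured compounds shown here, no measured pair shows what such a change does, so in this assay no shift beyond the usual scatter is expected. The estimated step is a 1.1-fold higher number from compound 1 to compound 3 (0.04 log units; within the scatter). For compound 3 the expected value is 5000 nM, with an estimated range of 2000 nM to 12000 nM.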

Compound 3, half-maximal inhibitory concentration: 1570 nM
Compound 3: middle estimate off by 3.2-fold (0.50 log units), on the high side; measured number below the stated range.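

Replacing (benzylamino)methyl with benzylamino at this chain carbon gives a 2.9-fold lower number from compound 1 to compound 3 (0.47 log units; beyond the scatter) in this assay and this modest step lies beyond the usual scatter. It shows that a small change in the chain linking the benzylamino end to the shared core can register in this cell read-out, and that here the shorter chain gives the lower number. No measurement shown here accounts for the step. As far as these compounds go, whether a still shorter chain would lower the number further remains open, as does the effect of a simple dimethylamino group in place of benzylamino.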